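Estimating Compound 3 from Two Measured Analogues

The source may hold more compounds than are shown below. What is called first, only, known or untested is meant among the compounds shown, and "the series" means these compounds.

Compound 2 `Cc1nn(-c2ccccc2)cc1/C=N/Nc1nc(Nc2ccccc2)nc(Nc2ccc(S(N)(=O)=O)cc2)n1` gives the lowest of the two numbers recorded in a functional assay on NCI-H23 cells (Homo sapiens) for inhibition, read by sulforhodamine B assay, with a stated time of 48 h (on this read-out lower numbers stand for higher toxicity in this test and higher numbers for lower toxicity in this test), at 7500 nM. Within the data shown here, its nearest neighbour, compound 1 `NS(=O)(=O)c1ccc(Nc2nc(N/N=C/c3ccc(C(F)(F)F)cc3)nc(Nc3ccccc3)n2)cc1`, gives 9250 nM in this assay, and the single measured step, a 1.2-fold lower number from compound 1 to compound 2 (0.09 log units; within the scatter), lies within the scatter. Compound 3 `NS(=O)(=O)c1ccc(Nc2nc(N/N=C/c3ccccn3)nc(Nc3ccccc3)n2)cc1` differs from compound 2 by pyridin-2-yl in place of 3-methyl-1-phenyl-1H-pyrazol-4-yl on a carbon with a double bond to nitrogen. Among the measured compounds shown here, the only step that bears on this change is the one already seen at the same position, a 1.2-fold lower number from compound 1 to compound 2 (0.09 log units; within the scatter), which swapped one aromatic group on the carbon with a double bond to nitrogen for another without moving the number beyond the scatter. On that basis compound 3 is expected to show no step beyond the scatter, a 1.1-fold higher number from compound 2 to compound 3 (0.03 log units; within the scatter). Compound 3 is therefore estimated at 8000 nM in this assay, with a range from 3000 nM to 22000 nM.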

Compound 3, concentration lethal to 50% of the cells: 8410 nM
Compound 3: the middle estimate sits 1.1-fold (0.02 log units) below what was measured; measured number inside the range.
By their numbers in this assay, from the lowest: compounds 2, 3 and 1 (each within the scatter of the next).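

Putting pyridin-2-yl, a single six-membered aromatic ring with 1 hetero atom, in place of the two-ring 3-methyl-1-phenyl-1H-pyrazol-4-yl gives a 1.1-fold higher number from compound 2 to compound 3 (0.05 log units; within the scatter) in this assay, so this change of group moves the number no further than the scatter. Against 4-(trifluoromethyl)phenyl, the same group gives a 1.1-fold lower number from compound 1 to compound 3 (0.04 log units; within the scatter), so among these three compounds, all with an aromatic ring on the carbon with a double bond to nitrogen, no group stands apart. No measurement available here accounts for this flat result.

The compounds shown leave open whether a non-aromatic group on this carbon, such as an amine, a carboxylic acid or a longer alkyl chain, would change the number. They also leave open how the number responds to changes elsewhere on the shared core.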